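A few compounds are considered here, and "the series" means these few. Any claim that something is new, unique, unknown or untested is made for them only; others in the source may bear on it.

Of the compounds shown here, two built on one shared core have so far been measured in a functional assay on cells (Panel ovarian (Carcinoma cell lines), Homo sapiens) for inhibition, read by sulforhodamine B assay, with a stated time of 48 h; a lower number here means that less compound is tolerated, a higher number that more compound is tolerated. Compound 1 `CN1CCN(CCCOc2cccc3nc(Nc4ccc(Cl)c(C(F)(F)F)c4)ccc23)CC1` gives 10300 nM in this assay. Compound 2 `CN1CCN(CCCOc2cccc3nc(Nc4cc(Cl)cc(Cl)c4)ccc23)CC1` gives 9180 nM in this assay. For the measured compounds named here, the single step between them, a 1.1-fold lower number from compound 1 to compound 2 (0.05 log units; within the scatter), exchanges one substituted phenyl on the nitrogen for another and moves nothing beyond the scatter. Compound 2 therefore stands at one of two numbers that cannot be told apart from each other.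

Compound 3 `CN1CCN(CCCOc2cccc3nc(Nc4cccc(Cl)c4)ccc23)CC1` has not yet been measured in this assay. It differs from compound 2 in one place: hydrogen in place of chloro on an aromatic carbon. Going by the values given here, the only measured step that bears on this change, a 1.1-fold lower number from compound 1 to compound 2 (0.05 log units; within the scatter), also reworked the substitution of that phenyl and stayed within the scatter. Among the compounds with values here, no measured pair shows what removing a single chloro from this phenyl does on its own. On that basis no step beyond the scatter is expected, and the estimated step is a 1.3-fold higher number from compound 2 to compound 3 (0.12 log units; within the scatter). Compound 3 is expected to give about 12000 nM in this assay, within a range from 5000 nM to 30000 nM.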

Compound 3, concentration lethal to 50% of the cells: 11500 nM
Beside the measured number, compound 3's estimate is 1.0-fold (0.02 log units) above it; the range from low to high includes it.
By their numbers in this assay, from the lowest: compounds 2, 1 and 3 (each within the scatter of the next).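

For the compounds shown here, this is the first measured pair that isolates a single chloro on this phenyl: in this assay, hydrogen in place of chloro on an aromatic carbon gives a step that stays within the scatter (a 1.3-fold higher number from compound 2 to compound 3 (0.10 log units; within the scatter)). Where the earlier step reworked the substitution as a whole, this one shows that the second chloro of the 3,5-dichlorophenyl can be exchanged for hydrogen without a readable change in the number, and the step to the 3-chlorophenyl from the 4-chloro-3-(trifluoromethyl)phenyl also stays within the scatter (a 1.1-fold higher number from compound 1 to compound 3 (0.05 log units; within the scatter)), so the three phenyl patterns in compounds 1, 2 and 3 cannot be told apart in this assay. No measurement is available that would explain why these numbers stay together.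

As far as these compounds go, all three compounds still carry at least one chloro on this phenyl, so it remains open whether an unsubstituted phenyl, or a methoxy group or a carboxylic acid on that ring, would give a step beyond the scatter. The chain and its terminal amine are also the same throughout, which leaves open what a longer chain or a different amine at that end would do.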